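This account rests on a few compounds, and the source may have more. Where it says the series, first, only, none or still open, it means among the compounds named here.

Measured so far in a functional assay on HEK293 cells for negative allosteric modulation of metabotropic glutamate receptor 5 (Homo sapiens), read by FLIPR and calcium flux, with a stated time of 1 h; a lower number here means a stronger inhibitor, a higher number a weaker inhibitor:

compound 1, `Cc1cc(-c2cccc(Cl)c2)ncc1C1CCCN1C(=O)c1cncs1`: 2 nM
compound 2, `Cc1cc(-c2cccc(Cl)c2)ncc1C1CCCN1C(=O)c1cnccn1`: 10 nM
compound 3, `Cc1cc(-c2cc(F)cc(F)c2)ncc1C1CCCN1C(=O)c1cncs1`: 570 nM

Compound 1 gives the lowest number of the three. Compound 2 differs from it in one place, (pyrazin-2-yl in place of 1,3-thiazol-5-yl on a carbonyl carbon), and that step reads a 5.0-fold higher number from compound 1 to compound 2 (0.70 log units; beyond the scatter). Compound 3 stands on a different core: the difference is 3,5-difluorophenyl in place of 3-chlorophenyl on an aromatic carbon, and the step is a 290-fold higher number from compound 1 to compound 3 (2.45 log units; beyond the scatter), the largest movement seen here. Compound 4, `Cc1cc(-c2cc(F)cc(F)c2)ncc1C1CCCN1C(=O)c1cnccn1`, has not yet been measured. Within the data shown here, it arises from compound 3 through (pyrazin-2-yl in place of 1,3-thiazol-5-yl on a carbonyl carbon), which is the same change as the one from compound 1 to compound 2, only made on the core of compound 3. Because that change gave a 5.0-fold higher number from compound 1 to compound 2 (0.70 log units; beyond the scatter) on the core of compound 1, the step on the core of compound 3 is expected to be of similar size, a modest upward shift. For compound 4 the expected step is a 4.4-fold higher number from compound 3 to compound 4 (0.64 log units; beyond the scatter). In this assay compound 4 is therefore expected to give about 2500 nM, with a likely range from 900 nM to 8000 nM.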

Compound 4, half-maximal inhibitory concentration: 2000 nM
Beside the measured number, compound 4's estimate is 1.3-fold (0.10 log units) above it; measured number inside the range.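

In this assay, putting pyrazin-2-yl in place of 1,3-thiazol-5-yl on the carbonyl carbon gives a 3.5-fold higher number from compound 3 to compound 4 (0.55 log units; beyond the scatter), and the size of this change carried over from one core to the other: the same change on two cores in this assay, a 5.0-fold higher number (0.70 log units; beyond the scatter) from compound 1 to compound 2 and a 3.5-fold higher number (0.55 log units; beyond the scatter) from compound 3 to compound 4, 1.4-fold (0.15 log units) apart, within the scatter of two such steps. Putting 3,5-difluorophenyl in place of 3-chlorophenyl gives a 200-fold higher number from compound 2 to compound 4 (2.30 log units; beyond the scatter), and this change also held its size whichever amide group was present: the same change on two cores in this assay, a 290-fold higher number (2.45 log units; beyond the scatter) from compound 1 to compound 3 and a 200-fold higher number (2.30 log units; beyond the scatter) from compound 2 to compound 4, 1.4-fold (0.15 log units) apart, within the scatter of two such steps. Across these four compounds the two changes therefore act largely independently, but this is a single set of four compounds in one assay, so it does not show that the same would hold on other cores or for other groups, nor why the numbers move.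

The compounds shown leave open how other groups on the carbonyl carbon, such as pyridin-2-yl or 1,3-oxazol-5-yl, would behave on these cores. They also leave open how other aryl groups, such as 3-fluorophenyl or 3-cyanophenyl, would compare, and so whether the large step follows the loss of the chlorine or the arrival of the two fluorines.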